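Three Amides, One Number, and a Methoxy Swap

This account rests on a few compounds, and the source may have more. Where it says the series, first, only, none or still open, it means among the compounds named here.

Of the compounds shown here, three sharing one core have been measured in a toxicity assay on THP-1 cells (Homo sapiens) for inhibition; on this read-out higher numbers stand for lower toxicity in this test and lower numbers for higher toxicity in this test. Compound 1 `CCCn1c(-c2ccc(OC)cc2)cnc1NC(=O)c1ccc(F)cc1` reaches only a limit in this assay, > 100000 nM. Compound 3 `COc1ccc(-c2cnc(NC(=O)C3CCOCC3)n2C)cc1` likewise shows only a limit in this assay, > 100000 nM. For the measured compounds named here, compound 2 `Cc1ccc(-c2cnc(NC(=O)c3ccc(F)cc3)n2C)cc1` is the one compound with an actual number: in this assay compound 2 gives 60000 nM. Going by the values given here, compound 2 therefore stands as the only measured value, while the other two sit at the limit of > 100000 nM in this assay, at which 2 of the 3 values shown sit.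

Compound 4 `COc1ccccc1-c1cnc(NC(=O)c2ccc(F)cc2)n1C` has not been measured. It differs from compound 2 in one place: 2-methoxyphenyl in place of 4-methylphenyl on an aromatic carbon. Among the compounds with values here, no step between two measured compounds is available, so the size of this change cannot be read from a measured pair. What the data do show is that compound 1, carrying a methoxy-bearing phenyl, gives only a limit in this assay, > 100000 nM. Compound 3, also carrying a methoxy-bearing phenyl, gives only a limit in this assay, > 100000 nM. Against this background the step from compound 2 to compound 4 is expected to be modest and toward lower toxicity, a 1.7-fold higher number from compound 2 to compound 4 (0.22 log units; within the scatter), with a fair chance that only a limit is recorded. Compound 4 is estimated at 100000 nM, within a range from 40000 nM to 250000 nM.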

Compound 4, half-maximal cytotoxic concentration: > 100000 nM
Compound 4 was reported as a limit; the forecaster's own chance of this, stated with the estimate: 55%; the middle value lies on the limit itself.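

For the compounds shown here, the swap of 4-methylphenyl for 2-methoxyphenyl gives the first step between two measured compounds in this set, on the aromatic carbon next to the ring nitrogen of the shared core, and in this assay it reads an at least 1.6-fold higher number from compound 2 to compound 4 (0.22 log units; that floor lies within the scatter). From the compounds shown here alone, compound 4 gives > 100000 nM, which is a limit and not a number, so the step is only a floor: its true size stays unknown, and the floor itself does not separate the two compounds beyond the usual scatter. Compound 2 remains the only compound with an actual number, and the rest of the set now gathers at one ceiling: the limit of > 100000 nM in this assay, at which 3 of the 4 values shown sit.

The compounds shown leave open how much of this step belongs to the methoxy group and how much to its place on the phenyl ring; the two change together here. They also leave open whether another group on that phenyl ring, such as an amine or a carboxylic acid, would give an actual number in this assay rather than another limit.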